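The compounds below may be only part of what the source reports. "The series", "measured", "known", "first", "only" and "open" are said of these compounds alone.

In a functional assay (mast cells) for inhibition, with Rattus norvegicus as the target (a lower number here means that less compound is needed, a higher number that more compound is needed for the effect), compound 1 `CC1CC/C(=N\Nc2ccc(O)cc2)c2ncc(C(=O)O)c(=O)n21`, which bears hydroxy, gives 1300 nM. Compound 2 `CCOc1ccc(N/N=C2\CCC(C)n3c2ncc(C(=O)O)c3=O)cc1`, which bears ethoxy, gives 17600 nM, and compound 3 `CC1CC/C(=N\Nc2ccc([N+](=O)[O-])cc2)c2ncc(C(=O)O)c(=O)n21`, which bears nitro, gives 8900 nM. Compound 3 is second highest of the three, and two measured steps fix its place: a 2.0-fold lower number from compound 2 to compound 3 (0.30 log units; within the scatter), and a 6.8-fold higher number from compound 1 to compound 3 (0.84 log units; beyond the scatter). Compound 4 `CC1CC/C(=N\Nc2ccc(-c3ccccc3)cc2)c2ncc(C(=O)O)c(=O)n21` has phenyl in place of nitro on an aromatic carbon. Among the compounds with values here, no measured step involves phenyl. Only the loss of hydroxy has moved the number beyond the scatter, as in a 14-fold higher number from compound 1 to compound 2 (1.13 log units; beyond the scatter), and compound 3 already lacks it. In this assay, the expected change is therefore small: a 1.3-fold higher number from compound 3 to compound 4 (0.13 log units; within the scatter). Compound 4 is expected at 12000 nM, with an estimated range of 4000 nM to 35000 nM.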

Compound 4, half-maximal effective concentration: 4400 nM
Compound 4: middle estimate off by 2.7-fold (0.44 log units), on the high side, and the stated range covers the measured number.
By their numbers in this assay, from the lowest: compound 1; then compound 4; then compounds 3 and 2 (each within the scatter of the next).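

In this assay phenyl, a ring entering on this aromatic carbon, gives a lower number than nitro (a 2.0-fold lower number from compound 3 to compound 4 (0.31 log units; beyond the scatter)) and than ethoxy (a 4.0-fold lower number from compound 2 to compound 4 (0.60 log units; beyond the scatter)), so a ring at this place does not by itself raise the number. Hydroxy still holds the lowest number of the four (a 3.4-fold higher number from compound 1 to compound 4 (0.53 log units; beyond the scatter)), and phenyl closes only part of that gap. Nothing available here accounts for these steps.

On these data alone, whether an amine or a carboxylic acid at this place would match hydroxy stays open. So does whether a phenyl ring carrying its own hydroxy would lower the number further.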